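Moving the chloro substituent on the aryl group of the shared core

This account rests on a few compounds, and the source may have more. Where it says the series, first, only, none or still open, it means among the compounds named here.

Measured compounds in an assay on cells for displacement of a labelled ligand from adenosine receptor A1 (Homo sapiens), read by scintillation counting and radioligand binding, with a stated time of 60 min, tested at 10 uM; a higher number here means more inhibition at the concentration tested (going by the name of the read-out), a lower number less inhibition:
compound 1 `Cn1cnc2c(N3CCCCC3)nc(-c3ccccc3O)nc21`, 50.5%
compound 2 `Cn1cnc2c(N3CCCCC3)nc(-c3cccc(O)c3)nc21`, 78.5%
compound 3 `Cn1cnc2c(N3CCCCC3)nc(-c3cccc(Cl)c3)nc21`, 22.4%

Compound 3 gives the lowest of the three numbers; the nearest is compound 1, a number 28.1 percentage points lower from compound 1 to compound 3 (beyond the scatter), and the furthest is compound 2, a number 56.1 percentage points lower from compound 2 to compound 3 (beyond the scatter). Compound 4 `Cn1cnc2c(N3CCCCC3)nc(-c3ccccc3Cl)nc21` is not yet measured. It differs from compound 3 in one place: 2-chlorophenyl in place of 3-chlorophenyl on an aromatic carbon. The same atoms are present, joined differently.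

Among the measured compounds shown here, one measured step bears on this change, the move of the hydroxy group between the same two positions: a number 28 percentage points higher from compound 1 to compound 2 (beyond the scatter), read in reverse it points downward. Whether a chloro group follows the same course is not shown by these compounds, and compound 3 already stands close to the bottom of the scale, so a drop of that size cannot be realised. A step slightly downward or within the scatter is therefore expected: a number 7.4 percentage points lower from compound 3 to compound 4 (within the scatter). Compound 4 is estimated at 15%, in the range 0% to 40%.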

Compound 4, a percentage reported as inhibition, at one concentration (the size of the read-out at that concentration, not a potency): 35.2%
Beside the measured number, compound 4's estimate is 20.2 percentage points below it; measured number inside the range.
By their numbers in this assay, from the lowest: compound 3; then compound 4; then compound 1; then compound 2.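

In this assay the positional order reverses with the substituent: the 3-hydroxyphenyl compound stands higher among the hydroxy pair, a number 28 percentage points higher from compound 1 to compound 2 (beyond the scatter), whereas the 2-chlorophenyl compound stands higher among the chloro pair, a number 12.8 percentage points higher from compound 3 to compound 4 (beyond the scatter). Compound 4 still stands under both hydroxy compounds, with a number 43.3 percentage points lower from compound 2 to compound 4 (beyond the scatter) and a number 15.3 percentage points lower from compound 1 to compound 4 (beyond the scatter), so chloro in place of hydroxy lowers the number at both positions. The size of that drop depends on the position: the same change on two cores in this assay, a number 56.1 percentage points lower (beyond the scatter) from compound 2 to compound 3 and a number 15.3 percentage points lower (beyond the scatter) from compound 1 to compound 4, 40.8 percentage points apart, beyond the scatter of two such steps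

Going by these compounds, whether an amino or a methoxy group on the same phenyl ring would follow the hydroxy order or the chloro order remains open. Readings at a single concentration also leave open how far these differences carry over to potency.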